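This account rests on a few compounds, and the source may have more. Where it says the series, first, only, none or still open, it means among the compounds named here.

Measured so far:
Compound 1 `Nc1scc(-c2ccc([N+](=O)[O-])cc2)c1C(=O)c1ccccc1` gives 47% in a functional assay on CHO cells for agonist activity at adenosine receptor A1 (Homo sapiens), read by fluorescence and ERK phosphorylation, with stated times of 30 min and 1.5 h, tested at 10 uM; on this read-out lower numbers stand for a weaker effect and higher numbers for a stronger effect at the one concentration tested.
Compound 2 `COc1ccc(-c2csc(N)c2C(=O)c2ccccc2)cc1` gives 52%.
Compound 3 `Nc1scc(-c2cccc([N+](=O)[O-])c2)c1C(=O)c1ccc(Cl)cc1` gives 42%.

Compound 4 `COc1cccc(-c2csc(N)c2C(=O)c2ccc(Cl)cc2)c1` has not yet been measured. It differs from compound 3 by methoxy in place of nitro on an aromatic carbon. The same kind of change, (methoxy in place of nitro on an aromatic carbon), links two measured compounds, where the incoming group sits para to a large group rather than meta to it, and there it made a step of a number 5 percentage points higher from compound 1 to compound 2 (within the scatter). The difference between the core of compound 1 and the core of compound 3 is not broken down here; their values show only a gap within the scatter.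

The step expected from compound 3 to compound 4 is estimated at a number 5 percentage points higher from compound 3 to compound 4 (within the scatter), because the matching change earlier gave a number 5 percentage points higher from compound 1 to compound 2 (within the scatter). For compound 4 the expected value in this assay is 47%, estimated to lie between 32% and 62%.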

Compound 4, a percentage reported as activity, at one concentration (the size of the read-out at that concentration, not a potency): 60%
For compound 4 the middle estimate is 13 percentage points below the measured one; low and high end bracket the measured number.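

On the core of compound 3, putting methoxy in place of nitro gives a number 18 percentage points higher from compound 3 to compound 4 (beyond the scatter). The same change on a second core gave a step that cannot be told apart from this one, so the two pairs fit a change that carries from one core to the other, though the size of that step remains uncertain: the same change on two cores in this assay, a number 5 percentage points higher (within the scatter) from compound 1 to compound 2 and a number 18 percentage points higher (beyond the scatter) from compound 3 to compound 4, 13 percentage points apart, within the scatter of two such steps Two pairs are too few to show that the step would hold on every core in this series, and the incoming group does not sit in the same place in both.

The compounds shown carry only nitro or methoxy at this spot, so how an amine, a carboxylic acid or a longer chain such as ethoxy would read there stays open. From the compounds shown here alone, whether the change from nitro to methoxy would give a similar step on a third core also stays open.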